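The source may hold more compounds than are shown below. What is called first, only, known or untested is meant among the compounds shown, and "the series" means these compounds.

Values so far in a physicochemical assay for lipophilicity, read by LC-MS, using the shake flask method, in phosphate buffer, measured as octanol-water partition, with a stated time of 2 h, at pH 7.4; a lower number here means a more polar compound, a higher number a more lipophilic compound

Compound 1 `OC[C@H]1O[C@H](n2cc(-c3ccccc3)nn2)[C@@H](O)[C@@H](O)[C@@H]1O` gives 0.21
Compound 2 `OC[C@H]1O[C@H](n2cc(-c3cccc(Cl)c3)nn2)[C@@H](O)[C@@H](O)[C@@H]1O` gives 1.22
Compound 3 `OC[C@H]1O[C@H](n2cc(-c3cccnc3)nn2)[C@@H](O)[C@@H](O)[C@@H]1O` gives -1.04

Compound 3 stands lowest of the three. The steps that reach it are a number 1.25 log units lower from compound 1 to compound 3 (beyond the scatter) and a number 2.26 log units lower from compound 2 to compound 3 (beyond the scatter). Compound 4 `OC[C@H]1O[C@H](n2cc(COc3ccccc3)nn2)[C@@H](O)[C@@H](O)[C@@H]1O` brings phenoxymethyl in place of pyridin-3-yl on an aromatic carbon with phenoxymethyl in place of pyridin-3-yl on an aromatic carbon. Its six-membered aromatic ring of carbon only matches compound 1, so the closest guide is a number 1.25 log units lower from compound 1 to compound 3 (beyond the scatter) read in reverse. The step of a number 1.01 log units higher from compound 1 to compound 2 (beyond the scatter) concerns a chloro group that compound 4 lacks. Among the compounds with values here, no measured compound carries phenoxymethyl. In this assay the estimated step is large and upward, a number 1.24 log units higher from compound 3 to compound 4 (beyond the scatter) as expected from that guide. Compound 4 is estimated at 0.2 (range -0.3 to 0.7).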

Compound 4, distribution coefficient: -0.18
The estimate for compound 4 lay 0.38 log units above the measured number; the range from low to high includes it.
By their numbers in this assay, from the lowest: compound 3; then compound 4; then compound 1; then compound 2.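

In this assay, compound 4 keeps the six-membered aromatic ring of carbon only found in compound 1, yet phenoxymethyl gives a number 0.39 log units lower from compound 1 to compound 4 (beyond the scatter). That ring alone therefore does not set the number at this position. Phenoxymethyl also gives a number 0.86 log units higher from compound 3 to compound 4 (beyond the scatter), and in place of 3-chlorophenyl it gives a number 1.40 log units lower from compound 2 to compound 4 (beyond the scatter).

No evidence is available to explain these steps. Going by these compounds, how an amine, a carboxylic acid or a longer chain carrying the same ring would compare at this position remains open.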